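Bis-indolylmethane series: aryl to heptyl at the central carbon

The source may report more compounds than this note shows. Statements on the series, on what has been measured and on what is new or still open speak of the compounds shown alone.

Measured so far in a functional assay on MCF7 cells (Homo sapiens) for inhibition, read by MTT assay, with a stated time of 48 h; a lower number here means a stronger inhibitor, a higher number a weaker inhibitor:
- compound 1 `Oc1ccc(C(c2c[nH]c3ccc(Br)cc23)c2c[nH]c3ccc(Br)cc23)cc1`: 3500 nM
- compound 2 `Oc1cccc(C(c2c[nH]c3ccc(Br)cc23)c2c[nH]c3ccc(Br)cc23)c1`: 2800 nM
- compound 3 `COc1ccc(C(c2c[nH]c3ccc(Br)cc23)c2c[nH]c3ccc(Br)cc23)c(OC)c1`: 77500 nM

Compound 3 stands at the highest number of the three. From compound 1 the step is a 22-fold higher number from compound 1 to compound 3 (1.35 log units; beyond the scatter) and from compound 2 it is a 28-fold higher number from compound 2 to compound 3 (1.44 log units; beyond the scatter); both are large. Between compound 1 and compound 2 the step is only a 1.3-fold lower number from compound 1 to compound 2 (0.10 log units; within the scatter).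

Compound 4 `CCCCCCCC(c1c[nH]c2ccc(Br)cc12)c1c[nH]c2ccc(Br)cc12` is not yet measured. The change from compound 3 is heptyl in place of 2,4-dimethoxyphenyl on a saturated chain carbon bound to two aromatic carbons.

Going by the values given here, no measured step covers an exchange of an aryl group for a chain on this carbon. The two steps into compound 3 show only that 2,4-dimethoxyphenyl sits far above the hydroxyphenyls in this assay ; heptyl shares neither the ring nor the acceptors of the group it replaces, so the direction is open. The estimate for compound 4 in this assay is 20000 nM, range 4000 nM to 100000 nM, which is expected to mean a step of a 3.9-fold lower number from compound 3 to compound 4 (0.59 log units; beyond the scatter), a moderate fall in number with wide uncertainty.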

Compound 4, half-maximal inhibitory concentration: 5500 nM
The estimate for compound 4 lay 3.6-fold (0.56 log units) above the measured number; the range from low to high includes it.
By their numbers in this assay, from the lowest: compounds 2, 1 and 4 (each within the scatter of the next); then compound 3.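

In this assay, an aromatic ring is not needed on this saturated chain carbon: heptyl, with no ring and no hydrogen-bond acceptors, gives a 14-fold lower number from compound 3 to compound 4 (1.15 log units; beyond the scatter). Set against the hydroxyphenyl compounds, the exchange gives a 2.0-fold higher number from compound 2 to compound 4 (0.29 log units; within the scatter) and a 1.6-fold higher number from compound 1 to compound 4 (0.20 log units; within the scatter), so a group with no hydrogen-bond donor matches both hydroxyphenyls here, and among the four compounds only compound 3 stands apart. No measurement at hand explains why 2,4-dimethoxyphenyl stands apart from the other three groups.

On these data alone, whether this level holds for a shorter chain such as butyl, a longer chain such as decyl, or a heptyl chain carrying an amine or a carboxylic acid remains open. Also open, as far as these compounds go, is whether a single methoxy group, as in 4-methoxyphenyl, would be enough to raise the number as 2,4-dimethoxyphenyl does.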